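The source may hold more compounds than are shown below. What is called first, only, known or untested is meant among the compounds shown, and "the series" means these compounds.

Measured compounds in a functional assay on MDA-MB-231 cells (Homo sapiens) for inhibition, read by MTT assay, with a stated time of 24 h; a lower number here means a stronger inhibitor, a higher number a weaker inhibitor:

Compound 1, `CCc1cc2ccccc2nc1-c1cc(-c2ccccc2)no1`, gives only a limit in this assay, > 100000 nM.
Compound 2, `CCCc1cc2ccccc2nc1-c1cc(-c2ccccc2)no1`, gives 47200 nM in this assay.
Compound 3, `CCCCc1cc2ccccc2nc1-c1cc(-c2ccc(C(F)(F)F)cc2)no1`, gives 10400 nM in this assay.

Compound 1 sits at the limit of > 100000 nM in this assay, at which 1 of the 3 values shown sits. Between compound 1 and compound 2 the only change is methyl in place of hydrogen on a saturated chain carbon, two bonds along the chain from an aromatic carbon, and it brings an at least 2.1-fold lower number from compound 1 to compound 2 (0.32 log units; beyond the scatter). Compound 3 carries a different chain and a trifluoromethyl group on its outer ring; the difference between the cores of compound 1 and compound 3 is not broken down here, and its value is the lowest of the two numbers measured, beyond the scatter from compound 2.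

The unmeasured compound 4, `CCCCCc1cc2ccccc2nc1-c1cc(-c2ccc(C(F)(F)F)cc2)no1`, differs from compound 3 by methyl in place of hydrogen on a saturated chain carbon, four bonds along the chain from an aromatic carbon. Among the measured compounds shown here, this is the same kind of change as the one from compound 1 to compound 2, but not the same: there the methyl entered two bonds along the chain from an aromatic carbon, here it enters four bonds along the chain from an aromatic carbon.

The expectation for compound 4 rests on the pair compound 1 and compound 2, where that kind of change gave an at least 2.1-fold lower number from compound 1 to compound 2 (0.32 log units; beyond the scatter), and on the lower number of compound 3 with its longer chain. The step from compound 3 to compound 4 is expected to be a 1.7-fold lower number from compound 3 to compound 4 (0.24 log units; within the scatter). Compound 4 is therefore estimated at 6000 nM in this assay, with a likely range from 2500 nM to 20000 nM.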

Compound 4, half-maximal inhibitory concentration: 22100 nM
For compound 4 the middle estimate is 3.7-fold (0.57 log units) below the measured one, outside the stated range (above it).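

In this assay, methyl in place of hydrogen on a saturated chain carbon, four bonds along the chain from an aromatic carbon, brings a 2.1-fold higher number from compound 3 to compound 4 (0.33 log units; beyond the scatter), so this kind of change does not carry over with the same outcome from one core to the other: the same change on two cores in this assay, an at least 2.1-fold lower number (0.32 log units; beyond the scatter) from compound 1 to compound 2 and a 2.1-fold higher number (0.33 log units; beyond the scatter) from compound 3 to compound 4, at least 4.5-fold (0.65 log units) apart, beyond the scatter of two such steps Compound 1 gives only a limit, so the earlier step has no exact size, and the gap between the two steps is likewise known only as a minimum: the limit of > 100000 nM in this assay, at which 1 of the 4 values shown sits. The comparison does not show what sets the two steps apart, since the methyl enters two bonds along the chain from an aromatic carbon in one pair and four bonds along in the other, while the cores also differ, and two pairs cannot separate the place of the change from the core that carries it.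

The compounds shown leave open whether a still longer chain on the core of compound 4 would continue the direction of the latest step, and whether the same chain change would behave alike with a chlorine or a nitrile in place of the trifluoromethyl group. They also leave open how an amine or a carboxylic acid on the chain would read in this assay.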